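Methylpiperazine in Place of Methylpyridine on the Shared Core

The source may hold more compounds than are shown below. What is called first, only, known or untested is meant among the compounds shown, and "the series" means these compounds.

Compound 1 `Cc1ccc(-c2ccc3[nH]c(=O)nc(-c4ccccc4)c3c2)cn1` is examined in an ADME assay on L6 cells (Rattus norvegicus) for cytotoxicity, read by fluorescence and resazurin assay, with a stated time of 72 h; a lower number here means that less compound is needed, a higher number that more compound is needed for the effect. There compound 1 gives only a limit, > 50000 nM. Compound 2 `Cc1ccncc1-c1ccc2[nH]c(=O)nc(-c3ccccc3)c2c1` likewise gives a limit in this assay, > 50000 nM. Compound 3 `O=c1nc(-c2ccccc2)c2cc(-c3ccccc3)ccc2[nH]1` also reaches only a limit in this assay, > 50000 nM. Because (the limit of > 50000 nM in this assay, at which 3 of the 3 values shown sit), compound 1 stands exactly where every value shown stands, and the steps a step that the two limits leave unreadable from compound 1 to compound 2, a step that the two limits leave unreadable from compound 1 to compound 3 and a step that the two limits leave unreadable from compound 2 to compound 3 cannot be read. Compound 4 `CN1CCN(c2ccc3[nH]c(=O)nc(-c4ccccc4)c3c2)CC1` differs from compound 1 in one place: 4-methylpiperazin-1-yl in place of 6-methylpyridin-3-yl on an aromatic carbon. Among the compounds with values here, no measured step gives a readable size for such a change, so the expectation rests on the shared limit alone. Compound 4 is expected to remain at that limit, with an estimate of 50000 nM ranging from 20000 nM to 100000 nM. The expected step of a number no higher from compound 1 to compound 4 (the limit leaves the size open) is thus none beyond the scatter.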

Compound 4, half-maximal effective concentration: > 50000 nM
Compound 4 was reported as a limit (the forecaster's own chance of this, stated with the estimate: 85%); the middle value lies on the limit itself.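

In this assay compound 4 joins compound 1, compound 2 and compound 3 at a limit, and no step among these four compounds can be read: the limit of > 50000 nM in this assay, at which 4 of the 4 values shown sit.

The compounds shown leave open whether the different groups on the shared core differ at all in the concentration needed for the effect.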